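The source may hold more compounds than are shown below. What is called first, only, known or untested is meant among the compounds shown, and "the series" means these compounds.

Measured in a functional assay on MCF7 cells (Homo sapiens) for inhibition, read by sulforhodamine B assay; on this read-out higher numbers stand for weaker inhibition and lower numbers for stronger inhibition:
compound 1, `O=C1C(Nc2cccc(Cl)c2)=CC(=O)c2c1nc1n2[C@H]2OC[C@@H](O)[C@H]2OC1`, 2970 nM
compound 2, `O=C1C=C(NCc2ccccc2)C(=O)c2c1nc1n2[C@H]2OC[C@@H](O)[C@H]2OC1`, > 8000 nM
compound 3, `O=C1C(Nc2ccc(C(F)(F)F)cc2)=CC(=O)c2c1nc1n2[C@H]2OC[C@@H](O)[C@H]2OC1`, > 4000 nM

Compound 2 carries a benzylamino group on the shared core. In this assay compound 2 is reported only as a limit, > 8000 nM, and no number stands for it; this is the limit of > 8000 nM in this assay, at which 1 of the 3 values shown sits. Going by the values given here, compound 1, with a (3-chlorophenyl)amino group in the same place, is the one compound of the three with a number, 2970 nM. Compound 3 also sits at a limit, > 4000 nM, which is the limit of > 4000 nM in this assay, at which 1 of the 3 values shown sits. Among the compounds with values here, the single step that can be sized, an at least 1.3-fold higher number from compound 1 to compound 3 (0.12 log units; that floor lies within the scatter), swaps one aryl group for another and stays within the scatter at its floor; it does not touch the benzyl-to-aryl question.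

Compound 4 is `O=C1C=C(Nc2cccc(F)c2)C(=O)c2c1nc1n2[C@H]2OC[C@@H](O)[C@H]2OC1`. It differs from compound 2 by 3-fluorophenyl in place of benzyl on an amine nitrogen. With a 3-fluorophenyl group on the amine nitrogen, compound 4 is closer in kind to compound 1 than to compound 2, so the expectation is that compound 4 moves from the limit of compound 2 down toward the number of compound 1, a step of an at least 2.2-fold lower number from compound 2 to compound 4 (0.35 log units; beyond the scatter), though a limit remains possible. The estimate for compound 4 is 3500 nM, expected between 1500 nM and 8000 nM.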

Compound 4, half-maximal inhibitory concentration: 5500 nM
Estimate against measurement, compound 4: 1.6-fold (0.20 log units) below, within the range that was stated.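

In this assay, 3-fluorophenyl in place of benzyl on the amine nitrogen gives an at least 1.4-fold lower number from compound 2 to compound 4 (0.16 log units; that floor lies within the scatter). Going by these compounds alone, this is the first pair that bears on the benzyl-to-aryl question at this position, and the (3-fluorophenyl)amino group yields a number where the benzylamino group yields none. Compound 2 is held only at a limit, so the real size of the step is unknown and only its floor can be read: the limit of > 8000 nM in this assay, at which 1 of the 4 values shown sits.

Left open is how much of the change belongs to the fluorine and how much to the ring sitting directly on the amine nitrogen, a question that a plain phenyl group at the same place would separate. Also open, going by these compounds, is whether a non-aromatic group on that nitrogen, such as cyclohexyl or a longer chain ending in an amine, gives a number in this assay at all.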